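This account rests on a few compounds, and the source may have more. Where it says the series, first, only, none or still open, it means among the compounds named here.

Of the compounds shown here, three built around a closely related skeleton have been tested in a functional assay on the whole organism (artery, strain albino) with Rattus norvegicus as the target, with a stated time of 60 min, at a dose of 10 mg/kg by the oral route; on this read-out lower numbers stand for less inhibition and higher numbers for more inhibition at the one dose given (going by the name of the read-out). Compound 1, `COc1ccc(C2N=C(SCc3ccc(Cl)cc3)NC(C)=C2C(=O)Nc2ccc(Br)cc2)cc1`, gives 12.3% in this assay. Compound 2, `COc1ccc(C2N=C(SCc3ccc(F)cc3)NC(C)=C2C(=O)Nc2ccc(Br)cc2)cc1`, differs from compound 1 in a single spot, (fluoro in place of chloro on an aromatic carbon), and compound 2 gives 8.7%. That single swap made a step of a number 3.6 percentage points lower from compound 1 to compound 2 (within the scatter), so the two numbers cannot be told apart. Compound 3, `CC1=C(C(=O)Nc2ccc([N+](=O)[O-])cc2)C(c2cccc([N+](=O)[O-])c2)N=C(SCc2ccc(Cl)cc2)N1`, carries a different core; the difference between the two cores is not broken down here. In this assay compound 3 gives 6.7%, which lies within the usual scatter of both compound 1 and compound 2, so none of the three can be called the more or the less inhibiting.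

Compound 4, `CC1=C(C(=O)Nc2ccc([N+](=O)[O-])cc2)C(c2cccc([N+](=O)[O-])c2)N=C(SCc2ccc(F)cc2)N1`, has not yet been measured. It stands to compound 3 exactly as compound 2 stands to compound 1, through the same change, (fluoro in place of chloro on an aromatic carbon). This change occurs twice among the compounds shown, and its one measured case moved the inhibition by an amount inside the scatter. The expected step is therefore a number 1.7 percentage points lower from compound 3 to compound 4 (within the scatter), resting on the measured step of a number 3.6 percentage points lower from compound 1 to compound 2 (within the scatter). For compound 4 the estimate is 5%, expected to fall between 0% and 14%, essentially the same low inhibition as its parent.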

Compound 4, a percentage reported as inhibition, in the whole organism at one dose (the size of the read-out at that dose, not a potency): 7.2%
For compound 4 the middle estimate is 2.2 percentage points below the measured one; low and high end bracket the measured number.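

In this assay, putting fluoro in place of chloro on the core of compound 3 gives a number 0.5 percentage points higher from compound 3 to compound 4 (within the scatter), so this step, like the earlier one, is too small to count as a real change. Set side by side, the two steps cannot be told apart, which means that in these four compounds the swap behaves the same way on both cores, leaving the inhibition indistinguishable from that of the parent: the same change on two cores in this assay, a number 3.6 percentage points lower (within the scatter) from compound 1 to compound 2 and a number 0.5 percentage points higher (within the scatter) from compound 3 to compound 4, 4.1 percentage points apart, within the scatter of two such steps This does not show that the swap has no effect at all or that it would behave alike on other cores, since two small steps cannot reveal a slight shift in either direction, and two cores are too few to make a rule.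

Only chloro and fluoro appear at this place on the ring, so the compounds shown leave open what an amine or a carboxylic acid there would do to the inhibition, or a longer chain in place of the benzyl group. They also leave open whether the swap would still make so little difference in a compound with much higher inhibition, or at a dose other than the single one given.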